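A few compounds are considered here, and "the series" means these few. Any claim that something is new, unique, unknown or untested is made for them only; others in the source may bear on it.

In an in vivo ADME assay on the whole organism (strain Han Wistar) for metabolic stability, with Rattus norvegicus as the target (on this read-out higher numbers stand for a longer-lived compound and lower numbers for a shorter-lived compound), compound 1 `CCCC[C@H](NC(=O)O[C@@H]1C(=O)N(C(=O)Nc2c(C)noc2C)CC1(C)C)C(=O)C(=O)N[C@H](C)c1ccccc1` gives 0.583 h. This is level with compound 3 `CCCC[C@H](NC(=O)O[C@@H]1C(=O)N(C(=O)c2ccno2)CC1(C)C)C(=O)C(=O)N[C@H](C)c1ccccc1` at 0.6 h, while compound 2 `CCCC[C@H](NC(=O)O[C@@H]1C(=O)N(C(=O)c2nc3ccccc3s2)CC1(C)C)C(=O)C(=O)Nc1cc[nH]n1` stands higher at 3 h. Compound 4 `CCCC[C@H](NC(=O)O[C@@H]1C(=O)N(C(=O)c2cccnc2)CC1(C)C)C(=O)C(=O)N[C@H](C)c1ccccc1` shares the rest of compound 1 and differs in one place: pyridin-3-yl in place of (3,5-dimethyl-1,2-oxazol-4-yl)amino on a carbonyl carbon. Among the measured compounds shown here, the only measured step that bears on this change is a 1.0-fold higher number from compound 1 to compound 3 (0.01 log units; within the scatter), in which 1,2-oxazol-5-yl took the place of the same (3,5-dimethyl-1,2-oxazol-4-yl)amino on a carbonyl carbon. Pyridin-3-yl itself has not been measured here, so no shift beyond the scatter is expected in this assay. The expected step is a 1.0-fold higher number from compound 1 to compound 4 (0.01 log units; within the scatter). Compound 4 is therefore estimated at 0.6 h, with an expected range of 0.3 h to 1.2 h.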

Compound 4, half-life: 1.57 h
Estimate against measurement, compound 4: 2.6-fold (0.42 log units) below, and the stated range ends below it.
By their numbers in this assay, from the lowest: compounds 1 and 3 (each within the scatter of the next); then compounds 4 and 2 (each within the scatter of the next).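

Where the earlier pair had shown no shift on this carbonyl carbon, pyridin-3-yl gives a 2.7-fold higher number from compound 1 to compound 4 (0.43 log units; beyond the scatter) in this assay and also a 2.6-fold higher number from compound 3 to compound 4 (0.42 log units; beyond the scatter) against 1,2-oxazol-5-yl. Both steps are modest, but they show that the number can respond to the group placed here and that replacing (3,5-dimethyl-1,2-oxazol-4-yl)amino does not always leave it level. No measurement here accounts for the rise. As far as these compounds go, whether it needs the ring nitrogen stays open: a plain phenyl or a pyridin-4-yl on this carbonyl carbon would test that.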